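The source may hold more compounds than are shown below. What is called first, only, known or untested is meant among the compounds shown, and "the series" means these compounds.

In a functional assay on B16 cells (Mus musculus) for inhibition (a lower number here means a stronger inhibitor, a higher number a weaker inhibitor), compound 1 `CC(C)CN(NC(=O)OCc1ccccc1)C(=O)CN(Cc1ccccc1)NC(=O)CBr` gives 1800 nM, while compound 2 `CC(C)CN(CC(=O)N(CC(C)C)NC(=O)OCc1ccccc1)/N=C/c1ccccc1B(O)O` gives 17300 nM. Compound 2 thus has the higher of the two numbers, making it the weaker inhibitor by a gap beyond the usual scatter. Compound 3 `CC(C)CN(NC(=O)OCc1ccccc1)C(=O)CN(Cc1ccccc1)/N=C/c1ccccc1B(O)O` has not yet been measured. It differs from compound 2 by phenyl in place of isopropyl on a saturated chain carbon bound to an amine nitrogen, which is phenyl in place of isopropyl on a saturated chain carbon bound to an amine nitrogen. Within the data shown here, no measured pair shows this change alone, so only a small drop in this assay, about the size of the scatter, is expected: the estimated step is a 1.7-fold lower number from compound 2 to compound 3 (0.24 log units; within the scatter). The estimated value for compound 3 is 10000 nM, with an expected range of 3000 nM to 30000 nM.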

Compound 3, half-maximal inhibitory concentration: 45100 nM
Beside the measured number, compound 3's estimate is 4.5-fold (0.65 log units) below it; the whole stated range lies below it.
By their numbers in this assay, from the lowest: compound 1; then compound 2; then compound 3.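

In this assay, the isobutyl-to-benzyl change, phenyl in place of isopropyl on a saturated chain carbon bound to an amine nitrogen, weakens inhibition, with a 2.6-fold higher number from compound 2 to compound 3 (0.42 log units; beyond the scatter), a modest step. With benzyl kept at that position, the group on the other amine nitrogen gives a large step, a 25-fold higher number from compound 1 to compound 3 (1.40 log units; beyond the scatter), when the bromine-bearing group gives way to the boron-bearing aromatic group. Nothing measured here explains either step. Still open, on these data alone, is how a longer chain or an amine would behave at the chain position. Also open, as far as these compounds go, is whether the bromine-bearing group would give a similar number with isobutyl instead of benzyl.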